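Moving a carboxyl group on a sulfonyl aryl ring

The source may hold more compounds than are shown below. What is called first, only, known or untested is meant among the compounds shown, and "the series" means these compounds.

In a functional assay for inhibition, with Homo sapiens as the target (on this read-out higher numbers stand for weaker inhibition and lower numbers for stronger inhibition), compound 1 `O=C(NCc1ccccc1)N[C@@H](CNC(=O)c1ccc2c(c1)C(=O)N(CCC1CCNCC1)C2)C(=O)O` gives 10 nM and compound 2 `O=C(O)c1ccc(S(=O)(=O)N[C@@H](CNC(=O)c2ccc3c(c2)C(=O)N(CCC2CCNCC2)C3)C(=O)O)cc1` gives 7 nM. These two numbers lie within the usual scatter of each other, so neither compound can be ranked above the other. The next compound, compound 3 `O=C(NC[C@H](NS(=O)(=O)c1ccccc1C(=O)O)C(=O)O)c1ccc2c(c1)C(=O)N(CCC1CCNCC1)C2`, has the same atoms as compound 2, joined differently: it carries 2-carboxyphenyl in place of 4-carboxyphenyl on a sulfonyl sulfur. Among the measured compounds shown here, only one measured step bears on this change, and only indirectly. That step, a 1.4-fold lower number from compound 1 to compound 2 (0.15 log units; within the scatter), put (4-carboxyphenyl)sulfonyl in place of benzylcarbamoyl on an amine nitrogen and stayed within the scatter. For the measured compounds named here, no measured compound carries 2-carboxyphenyl, so the data offer no direct guide to this swap. With so little to go on, no change beyond the scatter is expected in this assay, and no direction can be argued with confidence. The estimated step is a 1.4-fold higher number from compound 2 to compound 3 (0.15 log units; within the scatter). Compound 3 is expected at 10 nM, with an estimated range of 3 nM to 35 nM.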

Compound 3, half-maximal inhibitory concentration: 15 nM
Compound 3: the middle estimate sits 1.5-fold (0.18 log units) below what was measured; low and high end bracket the measured number.
By their numbers in this assay, from the lowest: compounds 2, 1 and 3 (each within the scatter of the next, the first and the last beyond it).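

In this assay, moving the carboxyl group from 4-carboxyphenyl to 2-carboxyphenyl on the sulfonyl sulfur gives a 2.1-fold higher number from compound 2 to compound 3 (0.33 log units; beyond the scatter). Among the compounds shown here, this modest step lies just beyond the usual scatter, so it is the first difference in this small set that can be read as real, and it shows that two compounds with the same atoms can be told apart by where the carboxyl group sits on this ring. The comparison with the urea-type compound is less clear, since replacing benzylcarbamoyl on the amine nitrogen with (2-carboxyphenyl)sulfonyl gives a 1.5-fold higher number from compound 1 to compound 3 (0.18 log units; within the scatter), which stays within the scatter, and no available evidence accounts for the effect of moving the carboxyl group.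

The compounds shown leave open whether the carboxylic acid on this ring is needed at all, a question that a plain phenyl group on the sulfonyl sulfur would address. As far as these compounds go, it is also open whether a methyl ester or a primary amide in place of that acid would show the same small dependence on ring position.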